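Swapping a piperidine for a bicyclic carbon ring on the amide

A few compounds are considered here, and "the series" means these few. Any claim that something is new, unique, unknown or untested is made for them only; others in the source may bear on it.

Within the data shown here, compound 3 `CC1CCN(C(=O)N2CC(c3nc(-c4cccc(Cl)c4)no3)C2)CC1` gives 865 nM in an assay on HEK293 cells for positive allosteric modulation of metabotropic glutamate receptor 5 (Homo sapiens), read by FLIPR (a lower number here means that less compound is needed, a higher number that more compound is needed for the effect), the second highest of the three numbers known here. Compound 2 `CC1CCC(C(=O)N2CC(c3nc(-c4cccc(Cl)c4)no3)C2)CC1` gives 1500 nM, and a 1.7-fold lower number from compound 2 to compound 3 (0.24 log units; within the scatter). Compound 1 `O=C([C@H]1CC2CCC1C2)N1CC(c2nc(-c3ccccc3)no2)C1` gives 120 nM; it carries the same bicyclic carbon group that now enters, but on a phenyl without chlorine, so it differs from compound 3 in two places. Compound 4 `O=C([C@H]1CC2CCC1C2)N1CC(c2nc(-c3cccc(Cl)c3)no2)C1` differs from compound 3 only on the carbonyl carbon: a group of 7 heavy atoms (7 carbon; 2 five-membered non-aromatic rings of carbon only) in place of a group of 7 heavy atoms (6 carbon, 1 nitrogen; one six-membered non-aromatic ring with 1 hetero atom), on a carbonyl carbon. Among the measured compounds shown here, no measured step covers this exact change; the lower number of compound 1 is the only hint. Compound 4 is therefore expected to sit nearer compound 1, giving an estimated 220 nM (range 60 nM to 800 nM), a step of a 3.9-fold lower number from compound 3 to compound 4 (0.59 log units; beyond the scatter) in this assay.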

Compound 4, half-maximal effective concentration: 74 nM
Estimate against measurement, compound 4: 3.0-fold (0.47 log units) above, and the stated range covers the measured number.
By their numbers in this assay, from the lowest: compounds 4 and 1 (each within the scatter of the next); then compounds 3 and 2 (each within the scatter of the next).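

In this assay, putting the bicyclic carbon group on the carbonyl carbon gives a 12-fold lower number from compound 3 to compound 4 (1.07 log units; beyond the scatter) and a 20-fold lower number from compound 2 to compound 4 (1.31 log units; beyond the scatter), so at this place it beats both six-membered rings, with or without a ring nitrogen. With this group in place, the chloro on the phenyl makes no clear difference: a 1.6-fold lower number from compound 1 to compound 4 (0.21 log units; within the scatter). Nothing measured here explains the gain.

Still open, as far as these compounds go, is whether a simpler group on the carbonyl carbon, such as cyclopentyl or tert-butyl, would keep the low number. Also open, from the compounds shown here alone, is what fluoro or methoxy in place of the chloro would do.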